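A few compounds are considered here, and "the series" means these few. Any claim that something is new, unique, unknown or untested is made for them only; others in the source may bear on it.

Working notes on the series, measured in a physicochemical assay for solubility, at pH 7.4; a higher number here means a more soluble compound, a lower number a less soluble compound:

- compound 1 `Cc1cc(NC(=O)Nc2cccc(C(N)=O)c2)c2ccccc2n1` gives 100 nM
- compound 2 `Cc1ccc(NC(=O)Nc2cc(C)nc3ccccc23)cc1` gives 1300 nM
- compound 3 `Cc1cc(NC(=O)Nc2cccc(OC(F)(F)F)c2)c2ccccc2n1` gives 600 nM

Of these three numbers, compound 3 holds the middle place, with the value of compound 2 higher and the value of compound 1 lower.

Next in line is compound 4 `Cc1cc(NC(=O)Nc2cccc(Cl)c2)c2ccccc2n1` with chloro in place of trifluoromethoxy on an aromatic carbon and the rest of compound 3 unchanged.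

Among the measured compounds shown here, only one measured step bears on this change: a 6.0-fold higher number from compound 1 to compound 3 (0.78 log units; beyond the scatter) with trifluoromethoxy in place of carbamoyl on an aromatic carbon. That step is modest, though beyond the scatter. For the measured compounds named here, it brought in the group that now leaves, but it says nothing directly about chloro, and no measured step has chloro entering. Compound 2 differs from compound 3 in more than one place, so it offers only a rough indication of the numbers seen without carbamoyl.

With so little evidence, no clear direction can be claimed, and a small change is expected. The estimated move is a 1.2-fold higher number from compound 3 to compound 4 (0.07 log units; within the scatter) and should stay within the scatter. In this assay compound 4 is expected at 700 nM as the central estimate. The estimated range for compound 4 runs from 250 nM to 2000 nM on current evidence.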

Compound 4, solubility: 800 nM
Compound 4: the middle estimate sits 1.1-fold (0.06 log units) below what was measured; low and high end bracket the measured number.
By their numbers in this assay, from the lowest: compound 1; then compounds 3, 4 and 2 (each within the scatter of the next, the first and the last beyond it).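

At this place, on an aromatic carbon meta to a large group, chloro and trifluoromethoxy are not told apart in this assay, with a 1.3-fold higher number from compound 3 to compound 4 (0.12 log units; within the scatter), whereas chloro in place of carbamoyl gives an 8.0-fold higher number from compound 1 to compound 4 (0.90 log units; beyond the scatter), a step of the same kind as the one already seen for trifluoromethoxy, so among these three compounds only the one carrying carbamoyl stands apart. The new compound also adds a comparison across the aryl group on the amide-type nitrogen: 3-chlorophenyl in place of 4-methylphenyl gives a 1.6-fold lower number from compound 2 to compound 4 (0.21 log units; within the scatter), so this change of both substituent and place does not separate the two compounds either. No measurement at hand explains any of these steps.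

The compounds shown leave open how an amine, a carboxylic acid, a nitrile or a methoxy group would read at this same place, and so whether carbamoyl is a lone case. They also leave open whether the steps seen here would hold with the methyl group on the shared core replaced by a longer chain.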